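Swapping the Amide Side Chain on a Melanocortin Ligand

The source may hold more compounds than are shown below. What is called first, only, known or untested is meant among the compounds shown, and "the series" means these compounds.

Compound 1, with the structure `CC(C)C[C@H](N)c1cc(C(F)(F)F)ccc1N1CCN(C(=O)COc2ccc3ccccc3c2)CC1`, was tested in an assay on HEK293 cells for displacement of a labelled ligand from Melanocortin receptor 4 (Homo sapiens) (a lower number here means a stronger inhibitor, a higher number a weaker inhibitor), where compound 1 gives 2000 nM. Of the two numbers available, this is the highest, so compound 1 is the weaker of the two measured binders. The other measured compound, compound 2, has the structure `CC(C)C[C@H](N)c1cc(F)ccc1N1CCN(C(=O)C(C)Cc2ccc(Cl)cc2)CC1`; in this assay compound 2 gives 390 nM, a number that lies beyond the usual scatter from that of compound 1. Among the compounds with values here, compound 2 differs from compound 1 in more than one place, so no single step between them can be read.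

The new compound 3 has the structure `COc1ccc(CC(C)C(=O)N2CCN(c3ccc(C(F)(F)F)cc3[C@@H](N)CC(C)C)CC2)cc1F`. Compared with compound 1 it carries 1-(3-fluoro-4-methoxybenzyl)ethyl in place of ((naphthalen-2-yl)oxy)methyl on a carbonyl carbon. The entering group resembles the group on the carbonyl carbon of compound 2, which shows the lower number of 390 nM. On that basis the step from compound 1 is expected to be downward in number, a gain beyond the scatter, as a 3.3-fold lower number from compound 1 to compound 3 (0.52 log units; beyond the scatter). In this assay compound 3 is therefore expected to give about 600 nM, within a range from 150 nM to 2500 nM.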

Compound 3, inhibition constant: 200 nM
Beside the measured number, compound 3's estimate is 3.0-fold (0.48 log units) above it; low and high end bracket the measured number.
By their numbers in this assay, from the lowest: compounds 3 and 2 (each within the scatter of the next); then compound 1.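

On the carbonyl carbon whose other neighbour is the amide-type nitrogen in a ring, changing the side chain alone shifts binding clearly: in this assay, putting 1-(3-fluoro-4-methoxybenzyl)ethyl in place of ((naphthalen-2-yl)oxy)methyl gives a 10-fold lower number from compound 1 to compound 3 (1.00 log units; beyond the scatter) while the rest of the molecule stays the same. The two groups have equal counts of heavy atoms, hydrogen-bond donors and hydrogen-bond acceptors, so those counts do not separate them, whereas the group that leaves has two six-membered aromatic rings, the group that enters has one, and fluorine is new. No supporting measurement is available to explain the change in number.

Several features change in this single swap, so the step cannot be assigned to any one of them, and the steps involving compound 2 cannot be read because it differs from the others in more than one place. From the compounds shown here alone, it remains open whether a plain benzyl group, or a 3-fluoro-4-hydroxybenzyl group, on this carbonyl carbon would give a similar number.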